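A few compounds are considered here, and "the series" means these few. Any claim that something is new, unique, unknown or untested is made for them only; others in the source may bear on it.

Compound 1 `O=C(O)c1ccc(NCc2cccc(Oc3ccccc3)c2)cc1` gives < 10000 nM in a functional assay on CHO cells for agonist activity at Free fatty acid receptor 1 (Homo sapiens); a lower number here means that less compound is needed, a higher number that more compound is needed for the effect.
Compound 2 `CC(C)(Oc1ccc(NCc2cccc(Oc3ccccc3)c2)cc1)C(=O)O` gives < 10000 nM in this assay.

Both of these values are limits of the assay rather than numbers, so compound 2 stands only at a limit in this assay. For the measured compounds named here, the single measured step, a step that the two limits leave unreadable from compound 1 to compound 2, cannot be read because of the limit of < 10000 nM in this assay, at which 2 of the 2 values shown sit. Compound 3 `CC(Cc1ccc(NCc2cccc(Oc3ccccc3)c2)cc1)C(=O)O` differs from compound 2 by 2-carboxypropyl in place of 1-carboxy-1-methylethoxy on an aromatic carbon. Going by the values given here, no measured step bears on this change, so neither a direction nor a size can be drawn from the data for this assay. Compound 3 is therefore expected at 2000 nM, in the range 200 nM to 10000 nM. The step that the limit leaves unreadable from compound 2 to compound 3 is estimated to lie within the scatter, with a fair chance that only a limit is reported again.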

Compound 3, half-maximal effective concentration: 100 nM
The estimate for compound 3 lay 20-fold (1.30 log units) above the measured number; measured number below the stated range.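

For the compounds shown here, no step to compound 3 can be read, from compound 1 or from compound 2, because both of those compounds give only a limit: the limit of < 10000 nM in this assay, at which 2 of the 3 values shown sit. The compounds shown leave open how large the real gap is between compound 3 and each of the other two.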